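This account rests on a few compounds, and the source may have more. Where it says the series, first, only, none or still open, it means among the compounds named here.

Compound 1 `COc1ccc(N2CCN(C(=S)SCc3ccc(C(=O)Nc4ccccc4N)cc3)CC2)cc1` gives 35.9% in a functional assay on A-375 cells (Homo sapiens) for antiproliferative activity, read by CCK-8 assay, with a stated time of 72 h, tested at 8 uM; on this read-out lower numbers stand for a weaker effect and higher numbers for a stronger effect at the one concentration tested. Compound 2 `Nc1ccccc1NC(=O)c1ccc(CSC(=S)N2CCN(Cc3cccnc3)CC2)cc1` gives 89.2% in this assay.

Compound 2 stands highest of the two numbers; its nearest neighbour is compound 1, and the step of a number 53.3 percentage points higher from compound 1 to compound 2 (beyond the scatter) lies beyond the scatter. Compound 3 `Nc1ccccc1NC(=O)c1ccc(CSC(=S)N2CCN(c3ccccc3F)CC2)cc1` has not yet been measured. It differs from compound 2 in one place: 2-fluorophenyl in place of (pyridin-3-yl)methyl on an amine nitrogen in a ring. Among the compounds with values here, the only measured step that bears on this change is the one from compound 1 to compound 2, in which a (pyridin-3-yl)methyl group replaced an aryl group on the same ring nitrogen and the read-out rose by a large margin. Compound 3 reverses that type of change, returning to an aryl group, though a different one than in compound 1. A step downward beyond the scatter is therefore expected, a number 39.2 percentage points lower from compound 2 to compound 3 (beyond the scatter), because the step of a number 53.3 percentage points higher from compound 1 to compound 2 (beyond the scatter) was large. Compound 3 is expected to give about 50%, within a range of 25% to 80%.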

Compound 3, a percentage reported as inhibition, at one concentration (the size of the read-out at that concentration, not a potency): 79.5%
The estimate for compound 3 lay 29.5 percentage points below the measured number, and the stated range covers the measured number.
By their numbers in this assay, from the lowest: compound 1; then compounds 3 and 2 (each within the scatter of the next).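

In this assay the step from (pyridin-3-yl)methyl to 2-fluorophenyl on the ring nitrogen gives a number 9.7 percentage points lower from compound 2 to compound 3 (within the scatter), so an aromatic ring of carbon only on this nitrogen is compatible with a read-out that cannot be told apart from that of the pyridine-bearing compound. The step from 4-methoxyphenyl to 2-fluorophenyl gives a number 43.6 percentage points higher from compound 1 to compound 3 (beyond the scatter), which shows that the low number of compound 1 does not hold for every phenyl-type group at this position and that the identity of the group on the phenyl ring matters. The data give no reason for this difference between the two substituted phenyl groups.

The compounds shown leave open how a plain phenyl or a benzyl group on this nitrogen would read out. They also leave open whether the fluorine or the methoxy group is the feature that separates compound 3 from compound 1.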